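The compounds below may be only part of what the source reports. "The series", "measured", "known", "first", "only" and "open" are said of these compounds alone.

Working notes on the series in a functional assay on PC-3 cells (Homo sapiens) for cytotoxicity, read by MTT assay, with a stated time of 72 h; on this read-out higher numbers stand for lower toxicity in this test and lower numbers for higher toxicity in this test. Compound 1 `CS/C(=N\C(=O)c1ccno1)NC(=O)c1ccno1` gives only a limit of the assay, > 100000 nM. Compound 2 `C[Se]/C(=N\C(=O)c1ccco1)NC(=O)c1ccco1` likewise reaches only a limit, > 100000 nM. Compound 2 thus stands at the edge of what the test reports, as the limit of > 100000 nM in this assay, at which 2 of the 2 values shown sit, shows. Compound 3 `CS/C(=N\C(=O)c1ccco1)NC(=O)c1ccco1` differs from compound 2 by a group of 2 heavy atoms (1 carbon, 1 sulfur; no ring) in place of a group of 2 heavy atoms (1 carbon, 1 selenium; no ring), on a carbon with a double bond to nitrogen. Within the data shown here, no measured pair separates these two groups, so no step size is known; given (the limit of > 100000 nM in this assay, at which 2 of the 2 values shown sit), no step beyond the scatter is expected in this assay. Compound 3 is therefore estimated to sit again near the limit, 200000 nM, a step that the limit leaves unreadable from compound 2 to compound 3 in size.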

Compound 3, concentration lethal to 50% of the cells: > 100000 nM
Compound 3: no number, only a limit; the forecaster's own chance of this, stated with the estimate: 85%; the middle value does not contradict the limit.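

In this assay, among these compounds, compound 2 and compound 3 both give only a limit, so no step between them can be read. Whether the methylsulfanyl group and its selenium counterpart differ in this assay remains open, with no compound shown giving a number.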